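The compounds below may be only part of what the source reports. "The series", "measured", "known", "first", "only" and "open" are said of these compounds alone.

Working notes on the series

All three measured compounds share one core with a hydrazone chain: compound 1 is `CCC(CC)=NNc1nc(-c2cccc([N+](=O)[O-])c2)cs1`, compound 2 is `CCCC/C(C)=N\Nc1nc(-c2cccc([N+](=O)[O-])c2)cs1` and compound 3 is `CCCC/C(CC)=N\Nc1nc(-c2cccc([N+](=O)[O-])c2)cs1`. In a functional assay, with a stated time of 30 min (on this read-out lower numbers stand for an effect already at smaller amounts and higher numbers for an effect only at larger amounts of compound), compound 1 gives 460000 nM. In this assay compound 2 gives 520000 nM, and compound 3 gives 550000 nM. The step of a 1.1-fold higher number from compound 1 to compound 2 (0.05 log units; within the scatter) and the step of a 1.1-fold higher number from compound 2 to compound 3 (0.02 log units; within the scatter) both stay within the scatter, so the three compounds cannot be told apart on this read-out.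

Compound 4 is `CCCCCC/C(C)=N\Nc1nc(-c2cccc([N+](=O)[O-])c2)cs1`; it has not yet been measured in this assay. It differs from compound 2 by ethyl in place of hydrogen on a saturated chain carbon, four bonds along the chain from a carbon with a double bond to nitrogen. The same kind of change was made from compound 1 to compound 3, namely (ethyl in place of hydrogen on a saturated chain carbon, two bonds along the chain from a carbon with a double bond to nitrogen), and it made the step of a 1.2-fold higher number from compound 1 to compound 3 (0.08 log units; within the scatter). The two places are not identical: from compound 1 to compound 3 the saturated chain carbon is two bonds along the chain from a carbon with a double bond to nitrogen, whereas from compound 2 to compound 4 it is four bonds along the chain. The two starting cores differ by a group of 7 heavy atoms (6 carbon, 1 nitrogen; no ring) in place of a group of 6 heavy atoms (5 carbon, 1 nitrogen; no ring), on a nitrogen on an aromatic ring.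

For compound 4 a step of a 1.2-fold higher number from compound 2 to compound 4 (0.06 log units; within the scatter) is expected, within the scatter, because a 1.2-fold higher number from compound 1 to compound 3 (0.08 log units; within the scatter) stayed within the scatter and the longer chains of compound 2 and compound 3 gave no step beyond it either. Compound 4 is therefore estimated at 600000 nM, with a range from 300000 nM to 1200000 nM.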

Compound 4, half-maximal effective concentration: 530000 nM
Compound 4: the middle estimate sits 1.1-fold (0.05 log units) above what was measured; measured number inside the range.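

In this assay the new step is a 1.0-fold higher number from compound 2 to compound 4 (0.01 log units; within the scatter), so on the core of compound 2, ethyl in place of hydrogen on a saturated chain carbon, four bonds along the chain from a carbon with a double bond to nitrogen, cannot be told apart from the parent on this read-out. Set beside the earlier case, the two cores give the same answer as far as this read-out can resolve: the same change on two cores in this assay, a 1.2-fold higher number (0.08 log units; within the scatter) from compound 1 to compound 3 and a 1.0-fold higher number (0.01 log units; within the scatter) from compound 2 to compound 4, 1.2-fold (0.07 log units) apart, within the scatter of two such steps. For the compounds shown here, this shows only that the change left no readable step on either core; it does not show that a step of real size would carry from one core to the other, since neither step rises above the scatter, the two places of the change are not identical and the comparison rests on two pairs alone.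

The compounds shown carry only plain saturated chains at the carbon with a double bond to nitrogen, and all of them lie at large amounts of compound on this read-out. As far as these compounds go, it stays open whether a longer chain, or an amine or a carboxylic acid on the chain, would give a step beyond the scatter, and whether such a step would then carry from one core to the other.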